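Bicyclic heteroaryl in place of methoxyphenyl on a benzoxazole

This account rests on a few compounds, and the source may have more. Where it says the series, first, only, none or still open, it means among the compounds named here.

In an assay on HEK293 cells for inhibition of Fatty-acid amide hydrolase 1 (Homo sapiens), read by fluorescence (on this read-out higher numbers stand for weaker inhibition and lower numbers for stronger inhibition), the measured compounds read as follows.
Compound 1 `NC(=O)c1cccc(-c2ccc3oc(NC4CCCCC4)nc3c2)c1` gives only a limit, > 1000 nM.
Compound 2 `NC(=O)Cn1ccc2cc(-c3ccc4oc(NC5CCCCC5)nc4c3)ccc21` gives 214 nM.
Compound 3 `COc1cccc(-c2ccc3oc(N4Cc5ccccc5C4)nc3c2)c1` gives 28 nM.

Compound 3 holds the lowest of the two numbers in this assay; compound 2 sits higher by a margin beyond the scatter. Compound 1 stands at the limit (the limit of > 1000 nM in this assay, at which 1 of the 3 values shown sits). Compound 4 `c1ccc2c(c1)CN(c1nc3cc(-c4ccc5nccn5c4)ccc3o1)C2` differs from compound 3 in one place: a group of 9 heavy atoms (7 carbon, 2 nitrogen; one five-membered aromatic ring with 2 hetero atoms, one six-membered aromatic ring with 1 hetero atom) in place of a group of 8 heavy atoms (7 carbon, 1 oxygen; one six-membered aromatic ring of carbon only), on an aromatic carbon. Among the compounds with values here, no measured pair in this assay follows such a change, so the expectation rests on compound 3 alone, with the rest of its structure unchanged. A step of modest size toward a weaker number is expected, a 2.1-fold higher number from compound 3 to compound 4 (0.33 log units; beyond the scatter). Compound 4 is therefore estimated at 60 nM, within a range from 15 nM to 300 nM.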

Compound 4, half-maximal inhibitory concentration: 14 nM
The estimate for compound 4 lay 4.3-fold (0.63 log units) above the measured number; measured number outside the range, below it.
By their numbers in this assay, from the lowest: compounds 4 and 3 (each within the scatter of the next); then compound 2. At a limit, above all of these: compound 1.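

In this assay, putting the group of one five-membered and one six-membered aromatic ring in place of 3-methoxyphenyl gives a 2.0-fold lower number from compound 3 to compound 4 (0.30 log units; within the scatter). This aromatic carbon therefore accepts a two-ring group carrying ring nitrogen as well as a single carbon-only aromatic ring, with the number staying within the scatter. No measured property shown here bears on this result.

On these data alone, whether a carboxylic acid or a simple amine at this position would leave the number similarly unchanged remains open. So does whether the same exchange would hold with the cyclohexylamino group found in compound 2 in place of the group at the other end of the core.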